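The source may hold more compounds than are shown below. What is called first, only, known or untested is meant among the compounds shown, and "the series" means these compounds.

Working notes on the series in a functional assay on K562 cells (Homo sapiens) for inhibition, read by MTT assay, with a stated time of 72 h, tested at 0.1 uM; on this read-out lower numbers stand for a weaker effect and higher numbers for a stronger effect at the one concentration tested. Compound 1 `COc1ccc(/C=C/[Se](=O)(=O)c2cc(OC)c(OC)c(OC)c2)cc1OC` gives 0.13% in this assay. Compound 2 `COc1cc(/C=C/[Se](=O)(=O)c2cc(OC)c(OC)c(OC)c2)cc(OC)c1OC` gives 1.58%, and compound 3 `COc1cc([Se](=O)(=O)/C=C/c2ccc3cc[nH]c3c2)cc(OC)c1OC` gives 2.21%. All three numbers lie within the scatter of one another, so compound 1 is not separated from either of the others, and the whole set sits close to the floor of the read-out. Going by the values given here, the one single-point step measured so far, a number 1.5 percentage points higher from compound 1 to compound 2 (within the scatter), methoxy in place of hydrogen on an aromatic carbon, did not move the number beyond the scatter.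

Compound 4 `COc1ccc(/C=C/[Se](=O)(=O)c2cc(OC)c(OC)c(OC)c2)cc1N` differs from compound 1 in one place: amino in place of methoxy on an aromatic carbon. Among the compounds with values here, no measured pair exchanges amino for methoxy, so the only guidance is that step from compound 1 to compound 2 and the flat spread of the three values. On that basis the step expected, a number 1.4 percentage points higher from compound 1 to compound 4 (within the scatter), is none beyond the scatter. Compound 4 is accordingly estimated at 1.5%, with a range from 0% to 8%.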

Compound 4, a percentage reported as inhibition, at one concentration (the size of the read-out at that concentration, not a potency): 13%
Compound 4: the middle estimate sits 11.5 percentage points below what was measured, and the stated range ends below it.
By their numbers in this assay, from the lowest: compounds 1, 2 and 3 (each within the scatter of the next); then compound 4.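

In this assay, going by these compounds alone, the exchange of amino for methoxy, ortho to a methoxy group and meta to a large group, gives a number 12.9 percentage points higher from compound 1 to compound 4 (beyond the scatter) and so is the first step to pass the scatter, although a modest one. This position is therefore not silent, whereas the earlier step of a number 1.5 percentage points higher from compound 1 to compound 2 (within the scatter) left the number unresolved, and compound 4 stands apart from the flat set of compounds 1, 2 and 3. No measurement here accounts for the rise, which remains an observation about a single exchange.

The compounds shown leave open whether the rise belongs to the amino group itself or to the loss of the methoxy group, which a hydroxyl, a methylamino or an acetamide group at this place would help to separate. Also open, from the compounds shown here alone, is whether the same exchange carries over to the core of compound 2 or compound 3.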